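A few compounds are considered here, and "the series" means these few. Any claim that something is new, unique, unknown or untested is made for them only; others in the source may bear on it.

Measured compounds:
compound 1 `O=C(Nc1ccc(Oc2ccnc3[nH]ccc23)cc1)c1cn(-c2ccc(Br)cc2)c2ccccc2c1=O`: 450 nM
compound 2 `O=C(Nc1ccc(Oc2ccnc3[nH]ccc23)cc1)c1cn(-c2ccc(Br)cc2F)c2ccccc2c1=O`: 1330 nM
compound 3 `Cn1ccc2c(Oc3ccc(NC(=O)c4cn(-c5ccc(Br)cc5)c5ccccc5c4=O)cc3F)ccnc21`: 1390 nM

Working notes. In a functional assay on A549 cells (Homo sapiens) for inhibition, read by MTT assay, with a stated time of 72 h (on this read-out lower numbers stand for stronger inhibition and higher numbers for weaker inhibition), compound 1 gives 450 nM, the lowest of the three numbers; its steps to compound 2 and to compound 3 are both beyond the scatter. The change fluoro in place of hydrogen on an aromatic carbon produces a 3.0-fold higher number from compound 1 to compound 2 (0.47 log units; beyond the scatter). Compound 3 differs from compound 1 in more than one place; the difference between the two cores is not broken down here. In this assay compound 3 gives 1390 nM, and compound 2 gives 1330 nM; these two numbers lie within the usual scatter of each other, so no order between them is claimed.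

Compound 4 `Cn1ccc2c(Oc3ccc(NC(=O)c4cn(-c5ccc(Br)cc5F)c5ccccc5c4=O)cc3F)ccnc21` has not yet been measured. It differs from compound 3 by fluoro in place of hydrogen on an aromatic carbon, the same change made from compound 1 to compound 2, at the same place. Only that one pairing is available to judge the change, so the expectation rests on a single observation.

The expected step for compound 4 in this assay is a 2.2-fold higher number from compound 3 to compound 4 (0.33 log units; beyond the scatter). This rests on the measured step of a 3.0-fold higher number from compound 1 to compound 2 (0.47 log units; beyond the scatter), read as the same change on a core that differs in ways not broken down here, which widens the range. Compound 4 is expected at about 3000 nM. For compound 4 the expected range is estimated to run from 1400 nM to 7000 nM.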

Compound 4, half-maximal inhibitory concentration: 1520 nM
Beside the measured number, compound 4's estimate is 2.0-fold (0.30 log units) above it; the measured number falls inside the stated range.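

In this assay, the change from 4-bromophenyl to 4-bromo-2-fluorophenyl on the core of compound 3 gives a 1.1-fold higher number from compound 3 to compound 4 (0.04 log units; within the scatter), so on this core the added fluoro leaves the number within the scatter. The change therefore does not carry over at the same size from one core to the other: the same change on two cores in this assay, a 3.0-fold higher number (0.47 log units; beyond the scatter) from compound 1 to compound 2 and a 1.1-fold higher number (0.04 log units; within the scatter) from compound 3 to compound 4, 2.7-fold (0.43 log units) apart, beyond the scatter of two such steps
This shows that, within these two pairs, the size of the step depends on the core it is made on, but it rests on one pair per core and gives no general rule for the series; since the two cores differ in more than one place, it also does not show which difference accounts for the gap, or why the step shrinks.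

Open, going by these compounds, is whether the methyl group or the further fluoro that set the two cores apart governs the size of the step, which a core carrying only one of them would separate. Also open, on these data alone, is whether a chloro or a methoxy group at the same place, ortho to a large group and meta to the bromo group, would follow the fluoro on either core.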